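Swapping methoxy for fluoro on a hydrazone-thiazole scaffold

A few compounds are considered here, and "the series" means these few. Any claim that something is new, unique, unknown or untested is made for them only; others in the source may bear on it.

Three compounds share one core and were tested in an ADME assay on NIH3T3 cells (Mus musculus) for cytotoxicity, read by MTT assay, with a stated time of 24 h; on this read-out higher numbers stand for weaker inhibition and lower numbers for stronger inhibition. Compound 1 `Cc1nnc(SCC(=O)N/N=c2/scc(-c3ccc(F)cc3)n2-c2ccccc2)s1` gives 383 ug/mL. Compound 2 `COc1ccc(-c2cs/c(=N/NC(=O)CSc3nnc(C)s3)n2-c2ccccc2)cc1` gives 300 ug/mL. Compound 3 `COc1ccc(-c2cs/c(=N/NC(=O)CSc3ncccn3)n2-c2ccccc2)cc1` gives 450 ug/mL. Compound 4 `O=C(CSc1ncccn1)N/N=c1/scc(-c2ccc(F)cc2)n1-c1ccccc1` awaits measurement.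

The core of compound 3 differs from that of compound 2 by pyrimidin-2-yl in place of 5-methyl-1,3,4-thiadiazol-2-yl on a sulfur, a step of a 1.5-fold higher number from compound 2 to compound 3 (0.18 log units; within the scatter). Compound 1 arises from compound 2 by fluoro in place of methoxy on an aromatic carbon, giving a 1.3-fold higher number from compound 2 to compound 1 (0.11 log units; within the scatter). The same change made on compound 3 leads to compound 4 by fluoro in place of methoxy on an aromatic carbon; both changes sit at the same place, so this is the same change.

Because that earlier step was a 1.3-fold higher number from compound 2 to compound 1 (0.11 log units; within the scatter), compound 4 is expected to give 500 ug/mL in this assay, between 300 ug/mL and 850 ug/mL. That expectation means a step of a 1.1-fold higher number from compound 3 to compound 4 (0.05 log units; within the scatter), resting on compound 3 at 450 ug/mL and on compound 1 at 383 ug/mL.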

Compound 4, half-maximal inhibitory concentration: > 500 ug/mL
Compound 4: only a limit was reported; the forecaster's own chance of this, stated with the estimate: 10%; the middle value sits exactly at the limit.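

In this assay compound 4 gives > 500 ug/mL, which is a limit of the assay and not a number. Going from 4-methoxyphenyl to 4-fluorophenyl on the pyrimidin-2-yl core gives an at least 1.1-fold higher number from compound 3 to compound 4 (0.04 log units; that floor lies within the scatter), so the result fits with the change carrying over but does not show that it acts the same way on both cores: the same change on two cores in this assay, a 1.3-fold higher number (0.11 log units; within the scatter) from compound 2 to compound 1 and an at least 1.1-fold higher number (0.04 log units; that floor lies within the scatter) from compound 3 to compound 4; the limit leaves it open whether they differ The swap to pyrimidin-2-yl, seen on the fluoro core as an at least 1.3-fold higher number from compound 1 to compound 4 (0.11 log units; that floor lies within the scatter), stays just as unsettled: the same change on two cores in this assay, a 1.5-fold higher number (0.18 log units; within the scatter) from compound 2 to compound 3 and an at least 1.3-fold higher number (0.11 log units; that floor lies within the scatter) from compound 1 to compound 4; the limit leaves it open whether they differ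

On these data alone, the true value of compound 4 remains unknown, and so does the full size of both new steps. Also open, as far as these compounds go, is whether an amine or a carboxylic acid at the place held by methoxy and fluoro would give similar numbers.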